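Sulfonamide series at the histamine receptor: methoxy to ethyl

The source may hold more compounds than are shown below. What is called first, only, known or untested is meant among the compounds shown, and "the series" means these compounds.

Measured compounds:
compound 1 `CC(=O)c1ccc(OCCCN2CC[C@H](NC(=O)c3ccc(C#N)cc3)C2)cc1`, 6100 nM
compound 2 `COc1ccc(S(=O)(=O)N[C@H]2CCN(CCCOc3ccc(C(=O)C4CC4)cc3)C2)cc1`, 1000 nM
compound 3 `CC(=O)c1ccc(OCCCN2CC[C@H](NC(=O)c3csc(-c4cccnc4)n3)C2)cc1`, 6200 nM

In an assay on isolated protein for binding affinity to histamine H2 receptor (Homo sapiens) (on this read-out lower numbers stand for stronger inhibition and higher numbers for weaker inhibition), compound 2 gives the lowest number of the three, at 1000 nM. Compound 1 gives 6100 nM and compound 3 gives 6200 nM, both well beyond the scatter from compound 2. Going by the values given here, compound 1 and compound 3 carry amide groups on the shared core and differ from compound 2 in several places at once, so their values show only that compound 2 stands apart, not which part of the change is responsible.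

Compound 4 `CCc1ccc(S(=O)(=O)N[C@H]2CCN(CCCOc3ccc(C(=O)C4CC4)cc3)C2)cc1` is not yet measured. It differs from compound 2 in one place: ethyl in place of methoxy on an aromatic carbon. Among the compounds with values here, no measured pair isolates this change, so there is no step to lean on. The expectation is a small step, none beyond the scatter, since the replacement keeps size and position and only removes one hydrogen-bond acceptor. The estimated step from compound 2 is a 1.3-fold higher number from compound 2 to compound 4 (0.11 log units; within the scatter). Compound 4 is expected at 1300 nM, between 450 nM and 3800 nM.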

Compound 4, inhibition constant: 330 nM
Beside the measured number, compound 4's estimate is 3.9-fold (0.60 log units) above it, outside the stated range (below it).
By their numbers in this assay, from the lowest: compound 4; then compound 2; then compounds 1 and 3 (each within the scatter of the next).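

In this assay, going by these compounds alone, the 4-methoxyphenyl to 4-ethylphenyl change gives the first single-place comparison, with a 3.0-fold lower number from compound 2 to compound 4 (0.48 log units; beyond the scatter). At this place, para to a large group, the number therefore responds to the group itself, and the hydrogen-bond acceptor of methoxy is not required for the lower number, as ethyl has none and compound 4 still gives the lowest number of the series. Nothing measured here bears on why the number falls with this change.

On these data alone, whether a longer chain such as propyl, or an amine or a carboxylic acid at the same place, would move the number further remains open. Also open, as far as these compounds go, is how much of the distance between the sulfonamides and the amide compounds, compound 1 and compound 3, comes from any single part of the structure.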